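This account rests on a few compounds, and the source may have more. Where it says the series, first, only, none or still open, it means among the compounds named here.

Compound 1 `Cc1ccc(/C=C2\CC[C@H]3C(C)(C)CCC[C@]3(C)[C@H]2CCC(C)CC(=O)O)cc1`: in a functional assay on THP-1 cells (Homo sapiens) for cytotoxicity, read by MTT assay, with a stated time of 24 h (on this read-out higher numbers stand for weaker inhibition and lower numbers for stronger inhibition), compound 1 reaches only a limit, > 200000 nM.
Compound 2 `COc1ccc(/C=C2\CC[C@H]3C(C)(C)CCC[C@]3(C)[C@H]2CCC(C)CC(=O)O)cc1OC`: in this assay compound 2 gives 178000 nM.
Compound 3 `CC(CC[C@H]1/C(=C/c2ccc(Br)cc2)CC[C@H]2C(C)(C)CCC[C@]12C)CC(=O)O`: in this assay compound 3 reaches only a limit, > 200000 nM.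

Compound 3 thus stands at a limit of this assay, not at a number, and the limit of > 200000 nM in this assay, at which 2 of the 3 values shown sit, shows that it shares this position with another compound. Compound 4 `CC(CC[C@H]1/C(=C/c2ccc(I)cc2)CC[C@H]2C(C)(C)CCC[C@]12C)CC(=O)O` differs from compound 3 by iodo in place of bromo on an aromatic carbon. Going by the values given here, the steps that bear on changes of the aryl group are an at least 1.1-fold lower number from compound 1 to compound 2 (0.05 log units; that floor lies within the scatter), a step that the two limits leave unreadable from compound 1 to compound 3 and an at least 1.1-fold higher number from compound 2 to compound 3 (0.05 log units; that floor lies within the scatter); none of them shows a readable step beyond the scatter. No shift beyond the scatter is therefore expected for compound 4 in this assay. Compound 4 is estimated at 200000 nM, with a range from 100000 nM to 400000 nM. This estimate means that a number no higher from compound 3 to compound 4 (the limit leaves the size open) is expected.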

Compound 4, half-maximal inhibitory concentration: 68000 nM
Compound 4: middle estimate off by 2.9-fold (0.47 log units), on the high side, outside the stated range (below it).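

In this assay, going by these compounds alone, the step of an at least 2.9-fold lower number from compound 3 to compound 4 (0.46 log units; beyond the scatter) is the first readable one beyond the scatter at this aromatic carbon, para to a large group, so the choice of halogen there does matter. The iodo compound also stands apart from the other two aryl groups, with a 2.6-fold lower number from compound 2 to compound 4 (0.42 log units; beyond the scatter) and an at least 2.9-fold lower number from compound 1 to compound 4 (0.46 log units; beyond the scatter) on the same read-out. Compound 3 stays at a limit, as does compound 1: the limit of > 200000 nM in this assay, at which 2 of the 4 values shown sit.

The compounds shown leave open whether a chloro or a nitrile group on this carbon would shift the read-out, and whether the iodo gain would survive with an amide in place of the carboxylic acid.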